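The source may hold more compounds than are shown below. What is called first, only, known or untested is meant among the compounds shown, and "the series" means these compounds.

In a functional assay on NSCLC cells (Homo sapiens) for inhibition (a lower number here means a stronger inhibitor of growth, a higher number a weaker inhibitor of growth), three compounds have been measured so far. Compound 1 (`CN1C/C(=C\c2cccs2)C(O)/C(=C/c2cccs2)C1`) gives 83900 nM, compound 2 (`COc1ccc(/C=C2\CN(C)Cc3c2nc(O)c(C#N)c3-c2ccc(OC)cc2)cc1`) gives 66600 nM, and compound 3 (`CN1C/C(=C\c2cccs2)C2=NN(C)C(c3cccs3)C2C1`) gives 86400 nM. Compound 3 therefore stands within the scatter of both others, and the three values cannot be ranked. Compound 4 (`CN1C/C(=C\c2cccs2)C2=NN(c3ccccc3)C(c3cccs3)C2C1`) has phenyl in place of methyl on an amine nitrogen in a ring. Among the compounds with values here, no measured pair differs in one place only, so the data offer no direct guide to this change. The expected step is a 1.6-fold lower number from compound 3 to compound 4 (0.20 log units; within the scatter), a small one towards a lower number that stays within the scatter. The estimate for compound 4 is 55000 nM, with an expected range from 18000 nM to 100000 nM.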

Compound 4, concentration for 50% growth inhibition: 20800 nM
Compound 4: the middle estimate sits 2.6-fold (0.42 log units) above what was measured, within the range that was stated.
By their numbers in this assay, from the lowest: compound 4; then compounds 2, 1 and 3 (each within the scatter of the next).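

In this assay, phenyl in place of methyl on this amine nitrogen gives a 4.2-fold lower number from compound 3 to compound 4 (0.62 log units; beyond the scatter), a modest step but one beyond the scatter, unlike the differences among the earlier values. This position therefore accepts an aromatic ring, and the group placed here can change growth inhibition. No measurement at hand explains the gain. From the compounds shown here alone, whether the aromatic ring itself matters, or any carbon group bigger than methyl would do, stays open. An ethyl, cyclohexyl or benzyl group on this nitrogen would help separate these possibilities.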